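Shifting the cyano group on the phenyl ring

The compounds below may be only part of what the source reports. "The series", "measured", "known", "first", "only" and "open" are said of these compounds alone.

Measured so far in a functional assay on PC-3 cells (Homo sapiens) for cytotoxicity, read by MTT assay, with a stated time of 24 h; a lower number here means a stronger inhibitor, a higher number a weaker inhibitor:
- compound 1, `COc1ccc(/C=C\C(=O)O)c(OCc2cn(-c3ccccc3I)nn2)c1CC=C(C)C`: "not determined" (no result reported)
- compound 2, `COc1ccc(/C=C\C(=O)O)c(OCc2cn(-c3ccccc3)nn2)c1CC=C(C)C`: 35000 nM
- compound 3, `COc1ccc(/C=C\C(=O)O)c(OCc2cn(-c3ccccc3C#N)nn2)c1CC=C(C)C`: "not determined" (no result reported)

All three share one core; they differ only in the phenyl ring attached to the aromatic nitrogen of the five-membered aromatic ring with three nitrogen. Going by the values given here, compound 3 stands without a single number in this assay, and compound 1 is a further entry without a single number, so the only anchor is compound 2, which in this assay gives 35000 nM, a weak inhibitor in this setting.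

The next compound is compound 4, `COc1ccc(/C=C\C(=O)O)c(OCc2cn(-c3cccc(C#N)c3)nn2)c1CC=C(C)C`. It differs from compound 3 in one place: 3-cyanophenyl in place of 2-cyanophenyl on an aromatic nitrogen. The two have the same atoms, joined differently.

Among the compounds with values here, no step between measured compounds exists to size this change. With compound 2 as the sole measured point, the value of compound 4 in this assay is expected to stay near that of compound 2, with no shift beyond the usual scatter expected in either direction, though the absence of a number for compound 3 leaves this open.

Compound 4 is estimated to give 35000 nM, within an expected range from 12000 nM to 100000 nM.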

Compound 4, half-maximal inhibitory concentration: 45500 nM
Estimate against measurement, compound 4: 1.3-fold (0.11 log units) below; measured number inside the range.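

With the nitrile placed as in 3-cyanophenyl, this assay shows a 1.3-fold higher number from compound 2 to compound 4 (0.11 log units; within the scatter), so at this place on the phenyl ring, cyano in place of hydrogen on an aromatic carbon does not separate compound 4 from compound 2. Going by these compounds alone, this is the first step that can be sized, and it shows that this one added group leaves both compounds in the same weak range in this setting. The steps that involve compound 1 or compound 3 cannot be read, so the measured values say nothing yet about how 3-cyanophenyl compares with 2-cyanophenyl, and no measured evidence here speaks to why the added nitrile leaves the reading within the scatter.

Open, on these data alone, is whether a different group on the phenyl ring, such as an amine, a carboxylic acid or a longer chain, would give a step beyond the scatter from compound 2. Also open, as far as these compounds go, is whether the iodine of compound 1 or the 2-cyanophenyl of compound 3 would read any differently from compound 2 in this assay.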